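Methyl on the five-membered ring of compound 1

A few compounds are considered here, and "the series" means these few. Any claim that something is new, unique, unknown or untested is made for them only; others in the source may bear on it.

Compound 1 `COC(=O)[C@@]1(C)CCC=C2[C@@H]1CC[C@@H](C)[C@]2(C)Cc1c[nH]c2ccccc12` is a tricyclic ester joined to an indole-type fragment through a single carbon. In a functional assay on SW1573 cells (Homo sapiens) for inhibition, read by sulforhodamine B assay, with a stated time of 48 h (on this read-out lower numbers stand for stronger inhibition of growth and higher numbers for weaker inhibition of growth), compound 1 gives 7300 nM, the lowest of the three numbers recorded here. Two near relatives carry a small group on the six-membered ring of that fragment: compound 2 `COC(=O)[C@@]1(C)CCC=C2[C@@H]1CC[C@@H](C)[C@]2(C)Cc1c[nH]c2ccc(C)cc12` gives 15000 nM, and compound 3 `COC(=O)[C@@]1(C)CCC=C2[C@@H]1CC[C@@H](C)[C@]2(C)Cc1c[nH]c2c(Cl)cccc12` gives 14000 nM. The step of a 2.1-fold higher number from compound 1 to compound 2 (0.31 log units; beyond the scatter) and the step of a 1.9-fold higher number from compound 1 to compound 3 (0.28 log units; within the scatter) both point towards weaker growth inhibition, the first just beyond and the second just within the usual scatter.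

Compound 4 `COC(=O)[C@@]1(C)CCC=C2[C@@H]1CC[C@@H](C)[C@]2(C)Cc1c(C)[nH]c2ccccc12` differs from compound 1 in one place: methyl in place of hydrogen on an aromatic carbon, on an aromatic carbon of a five-membered aromatic ring with one nitrogen, part of a fused system of two rings, next to the ring nitrogen and next to the ring atom that bears the large group. Among the measured compounds shown here, no measured step puts a methyl at that spot; the two steps above concern a different ring, so they bear only loosely on it. Given that both small additions to compound 1 gave a modest rise, a similar modest rise or no change beyond the scatter is expected, as the step of a 1.4-fold higher number from compound 1 to compound 4 (0.14 log units; within the scatter). Compound 4 is therefore estimated at 10000 nM, likely within 4000 nM to 25000 nM.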

Compound 4, concentration for 50% growth inhibition: 14000 nM
Compound 4: middle estimate off by 1.4-fold (0.15 log units), on the low side; low and high end bracket the measured number.
By their numbers in this assay, from the lowest: compounds 1, 3, 4 and 2 (each within the scatter of the next, the first and the last beyond it).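

In this assay, methyl in place of hydrogen on an aromatic carbon of the five-membered aromatic ring gives a 1.9-fold higher number from compound 1 to compound 4 (0.28 log units; within the scatter) and so stays within the scatter. Among the compounds shown here, this is the first reading at this position, and it shows that the carbon next to the ring nitrogen can carry a methyl without a change that can be told apart from compound 1. The single step gives no sign of stronger growth inhibition from a methyl here, and no measurement shown explains the result.

Only one small group at this carbon is shown, so a single methyl cannot say how far the position would accept something else. As far as these compounds go, whether an ethyl group, a longer chain, an amine or a carboxylic acid here would match compound 1 or move the number in either direction remains open.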